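The source may hold more compounds than are shown below. What is called first, only, known or untested is meant among the compounds shown, and "the series" means these compounds.

Measured compounds: compound 1 `CC(C)(C)n1ncc(OCc2nnc(-c3ccccc3Cl)o2)c(Cl)c1=O`, compound 2 `CC(C)(C)n1ncc(OCc2nnc(-c3c(F)c(F)c(F)c(F)c3F)o2)c(Cl)c1=O`, compound 3 `COc1c(F)c(F)cc(-c2nnc(COc3cnn(C(C)(C)C)c(=O)c3Cl)o2)c1F`.

In a functional assay on the whole organism for inhibition, with Mythimna separata as the target, with a stated time of 5 days (a higher number here means that more compound is needed for the effect, a lower number that less compound is needed), compound 1 gives 61200 nM. In this assay compound 2 gives 271000 nM, a number beyond the scatter above that of compound 1, so compound 1 has the lower of the two numbers. Compound 3 reaches only a limit in this assay, > 299000 nM, which is the limit of > 299000 nM in this assay, at which 1 of the 3 values shown sits, and not a number. Compound 4 `CC(C)(C)n1ncc(OCc2nnc(-c3cccc(F)c3)o2)c(Cl)c1=O` has not been measured in this assay; it differs from compound 1 by 3-fluorophenyl in place of 2-chlorophenyl on an aromatic carbon. Within the data shown here, no step between measured compounds is known, so he expects a step from compound 1 to compound 4 of a 1.8-fold higher number from compound 1 to compound 4 (0.25 log units; within the scatter), toward a higher number. For compound 4 he estimates 110000 nM, between 30000 nM and 320000 nM.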

Compound 4, half-maximal effective concentration: 7100 nM
Compound 4: the middle estimate sits 15-fold (1.19 log units) above what was measured, and the stated range ends above it.
By their numbers in this assay, from the lowest: compound 4; then compound 1; then compound 2. At a limit, above all of these: compound 3.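

In this assay, among these compounds, putting 3-fluorophenyl in place of 2-chlorophenyl gives the first step that can be read at this place on the five-membered aromatic ring: an 8.6-fold lower number from compound 1 to compound 4 (0.94 log units; beyond the scatter). The group at this place can thus shift the number beyond the scatter, and toward less compound needed. Nothing measured here accounts for the step. The change swaps both the halogen and where it sits on the phenyl ring, and the compounds shown do not separate the two. From the compounds shown here alone, how a phenyl ring carrying an amine or a carboxylic acid would read remains open.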